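This account rests on a few compounds, and the source may have more. Where it says the series, first, only, none or still open, it means among the compounds named here.

Compound 1 `CO[C@@H]1O[C@H](CN([C@@H](C(=O)O)C(C)C)S(=O)(=O)c2ccc(-c3ccccc3)cc2)[C@@H](O)[C@H](O)[C@H]1O`: 2200 nM
Compound 2 `CO[C@@H]1O[C@H](CNC(=S)NCCN([C@@H](C(=O)O)C(C)C)S(=O)(=O)c2ccc(-c3ccccc3)cc2)[C@@H](O)[C@H](O)[C@H]1O`: 520 nM
Compound 3 `CO[C@@H]1O[C@H](CN([C@@H](C(=O)O)C(C)C)S(=O)(=O)c2ccc(-c3ccccc3)cc2)[C@@H](OC(C)=O)[C@H](OC(C)=O)[C@H]1NC(C)=O`: 1240 nM

All three were tested in an assay on isolated protein for inhibition of matrix metalloproteinase-9 (Homo sapiens), read by fluorescence, with stated times of 3 h, 10 s and 15 min; on this read-out higher numbers stand for weaker inhibition and lower numbers for stronger inhibition. Compound 1 gives the highest number of the three, that is, the weakest inhibition seen here. Compound 3 lies close by: its number sits within the usual scatter of that of compound 1, so the two cannot be told apart. Compound 2 sits further away, beyond the scatter, and so inhibits more strongly than compound 1.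

Compound 4 `CO[C@@H]1O[C@H](CN([C@@H](C(=O)O)C(C)C)S(=O)(=O)c2ccc(-c3ccccc3)cc2)[C@@H](O)[C@H](O)[C@H]1NC(C)=O` has not been measured yet. It differs from compound 1 in a single place: acetamido in place of hydroxy on a saturated ring carbon. For the measured compounds named here, no pair of measured compounds isolates this exact change, so the step is expected to be modest, a 1.5-fold lower number from compound 1 to compound 4 (0.17 log units; within the scatter), toward a somewhat lower number but not clearly beyond the scatter. Compound 4 is therefore estimated at 1500 nM, with a range from 600 nM to 4000 nM.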

Compound 4, half-maximal inhibitory concentration: 890 nM
Estimate against measurement, compound 4: 1.7-fold (0.23 log units) above; the range from low to high includes it.
By their numbers in this assay, from the lowest: compounds 2, 4, 3 and 1 (each within the scatter of the next, the first and the last beyond it).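

Placing acetamido instead of hydroxy on this saturated ring carbon gives a 2.5-fold lower number from compound 1 to compound 4 (0.39 log units; beyond the scatter) in this assay. For the compounds shown here, this is the first single-place change in the set, and it shows that this position can take the larger group and that the number responds to the swap. Nothing measured here explains why the number falls. Going by these compounds, it remains open whether an amine or a longer acylamino chain on the same carbon would lower the number further or raise it again. On these data alone, whether the same swap would act alike on compound 2 also remains open.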